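Ethynyl for iodo on a nucleoside scaffold: cytotoxicity outlook

The source may hold more compounds than are shown below. What is called first, only, known or untested is meant among the compounds shown, and "the series" means these compounds.

Two nucleoside analogues have been measured in an ADME assay on MRC5 cells (Homo sapiens), read by MTT assay, with a stated time of 72 h; on this read-out higher numbers stand for weaker inhibition and lower numbers for stronger inhibition. Compound 1 `COc1nc(N)nc2c1c(-c1cc3ccccc3o1)cn2[C@@H]1O[C@H](CO)[C@@H](O)[C@H]1O` gives 22700 nM. Compound 2 `COc1ncnc2c1c(I)cn2[C@@H]1O[C@H](CO)[C@@H](O)[C@H]1O` gives 63000 nM, the highest of the two numbers and beyond the scatter away from compound 1, so compound 2 shows the weaker inhibition of growth. Compound 3 `C#Cc1cn([C@@H]2O[C@H](CO)[C@@H](O)[C@H]2O)c2ncnc(OC)c12` has not yet been measured; it differs from compound 2 by ethynyl in place of iodo on an aromatic carbon. Within the data shown here, with no single-change step available as a guide, the step of a 1.3-fold lower number from compound 2 to compound 3 (0.10 log units; within the scatter) is expected to be small and not beyond the usual scatter. Compound 3 is therefore estimated at 50000 nM, with a likely range from 20000 nM to 125000 nM.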

Compound 3, half-maximal inhibitory concentration: > 100000 nM
Compound 3 ended at the assay's limit; the forecaster's own chance of this, stated with the estimate: 20%; at least 2.0-fold (0.30 log units) between middle value and limit.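

In this assay, compound 3 gives > 100000 nM, which is a limit of the assay and not a number. Ethynyl in place of iodo is the first change in one place seen at this aromatic carbon, and it reads as an at least 1.5-fold higher number from compound 2 to compound 3 (0.20 log units; that floor lies within the scatter). It brings no stronger inhibition, but how much weaker it is, if at all, cannot be read: the limit of > 100000 nM in this assay, at which 1 of the 3 values shown sits.

The compounds shown leave open how an amine or a longer chain on this aromatic carbon would read.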